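A few compounds are considered here, and "the series" means these few. Any claim that something is new, unique, unknown or untested is made for them only; others in the source may bear on it.

Measured compounds in an ADME assay on PC-3 cells (Homo sapiens) for cytotoxicity, read by WST assay, tested at 100 uM; a lower number here means less inhibition, a higher number more inhibition at the concentration tested (going by the name of the read-out):
compound 1 `C=Cc1cccc(C(=O)N2CCCC(C(=O)Nc3ccc(Cl)cc3)C2)c1` gives 0%;
compound 2 `O=C(Nc1cccc(OCCc2ccccn2)c1)C1CCCN(C(=O)c2cc(C(F)(F)F)cc(C(F)(F)F)c2)C1` gives 5%;
compound 3 `Cc1nc(-c2cccc(C(=O)N3CCCC(C(=O)Nc4ccc(Cl)cc4)C3)c2)cs1` gives 1%.

Compound 2 stands highest of the three numbers, but its nearest neighbour is compound 3, a number within the scatter of it, and compound 1 is also within the scatter. In effect all three measured compounds sit near the bottom of the read-out in this assay.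

Compound 4 `O=C(Nc1cccc(S(=O)(=O)N2CCCC2)c1)C1CCCN(C(=O)c2cc(C(F)(F)F)cc(C(F)(F)F)c2)C1` is the unmeasured analogue of compound 2. The change is (pyrrolidin-1-yl)sulfonyl in place of 2-(pyridin-2-yl)ethoxy on an aromatic carbon. Within the data shown here, the only measured step, a number 1 percentage points higher from compound 1 to compound 3 (within the scatter), concerns a different position of a different compound pair and is within the scatter; it offers no direct guide to a change at the position altered in compound 4. Among the measured compounds shown here, nothing among the measured compounds shows a change at this position moving the read-out beyond the scatter.

Compound 4 is therefore expected to stay close to compound 2, with an estimated step of a number 1 percentage points lower from compound 2 to compound 4 (within the scatter). The estimate for compound 4 in this assay is 4%, with a range from -8% to 16%.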

Compound 4, a percentage reported as inhibition, at one concentration (the size of the read-out at that concentration, not a potency): 0%
Beside the measured number, compound 4's estimate is 4 percentage points above it; the measured number falls inside the stated range.
By their numbers in this assay, from the lowest: compounds 1, 4, 3 and 2 (each within the scatter of the next).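

In this assay, putting (pyrrolidin-1-yl)sulfonyl in place of 2-(pyridin-2-yl)ethoxy on an aromatic carbon gives a number 5 percentage points lower from compound 2 to compound 4 (within the scatter). This is the only step shown at this position, and it indicates that these two groups, one carrying a six-membered aromatic ring and the other a five-membered non-aromatic ring, can be exchanged here without the read-out moving beyond the scatter. Nothing measured here offers an explanation for this result.

Going by these compounds, it remains open whether an amine, a carboxylic acid or a longer chain at this position would also leave the read-out within the scatter of compound 2. On these data alone, it is equally open whether the same exchange would give a similar step on the core of compound 1, where the other groups differ.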